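The source may hold more compounds than are shown below. What is called first, only, known or untested is meant among the compounds shown, and "the series" means these compounds.

The shared core carries either an ester or an amide on its carbonyl carbon. Compound 1 `CCOC(=O)c1c(O)c2cccnc2n(-c2ccccc2)c1=O` bears ethoxy there and gives 23.5% in a functional assay on the whole organism for inhibition, with Rattus norvegicus as the target, read by paw edema, at a dose of 100 mg/kg by the oral route; on this read-out lower numbers stand for less inhibition and higher numbers for more inhibition at the one dose given (going by the name of the read-out). Compound 2 `COc1ccc(NC(=O)c2c(O)c3cccnc3n(-c3ccccc3)c2=O)cc1` carries (4-methoxyphenyl)amino and gives 0.3%; compound 3 `O=C(Nc1ccc(Cl)cc1)c1c(O)c2cccnc2n(-c2ccccc2)c1=O` carries (4-chlorophenyl)amino and gives 11.6%. Compound 2 stands lowest of the three, with compound 3 nearest and compound 1 furthest above it.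

Compound 4 `Cc1cnccc1NC(=O)c1c(O)c2cccnc2n(-c2ccccc2)c1=O` has not been measured. Its change from compound 2 is 3-methylpyridin-4-yl in place of 4-methoxyphenyl on an amide-type nitrogen; the group that leaves is a six-membered aromatic ring of carbon only, the one that enters is a six-membered aromatic ring with one hetero atom.

Within the data shown here, two measured steps bear on this. Replacing ethoxy by an arylamino gave a number 23.2 percentage points lower from compound 1 to compound 2 (beyond the scatter) and a number 11.9 percentage points lower from compound 1 to compound 3 (beyond the scatter), so both amides sit below the ester. Within the amides, swapping the group on the aromatic ring gave a number 11.3 percentage points higher from compound 2 to compound 3 (beyond the scatter). A further swap of the ring itself is therefore expected to give a modest rise at most, a number 7.7 percentage points higher from compound 2 to compound 4 (within the scatter). Compound 4 is estimated at 8%, between 0% and 22%.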

Compound 4, a percentage reported as inhibition, in the whole organism at one dose (the size of the read-out at that dose, not a potency): 26.9%
Compound 4: middle estimate off by 18.9 percentage points, on the low side; measured number outside the range, above it.
By their numbers in this assay, from the lowest: compound 2; then compound 3; then compounds 1 and 4 (each within the scatter of the next).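

Replacing the whole aromatic ring on the amide-type nitrogen, rather than only the group it carries, moves the number in this assay: 3-methylpyridin-4-yl gives a number 26.6 percentage points higher from compound 2 to compound 4 (beyond the scatter) and a number 15.3 percentage points higher from compound 3 to compound 4 (beyond the scatter) in this comparison. The two earlier amides both sat below the ester, but this one does not, with a number 3.4 percentage points higher from compound 1 to compound 4 (within the scatter), so an amide on this carbonyl carbon does not always go with a lower number. No measurement here explains the rise.

The compounds shown change the ring nitrogen and the methyl together, so which of the two goes with the higher number stays open. A pyridin-4-yl without the methyl, or a 3-methylphenyl, on the same nitrogen would separate them.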